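Working notes: the aryl swap from compound 3 to compound 4

The source may hold more compounds than are shown below. What is called first, only, known or untested is meant among the compounds shown, and "the series" means these compounds.

Measured in a functional assay on HepG2 cells (Homo sapiens) for antiproliferative activity, read by MTT assay, with a stated time of 72 h; on this read-out lower numbers stand for stronger inhibition and higher numbers for weaker inhibition:
- compound 1 `O=C(N/N=C/c1ccc(Br)cc1)Nc1ccc(Oc2ccnc3[nH]ccc23)c(F)c1`: 1000 nM
- compound 2 `N#Cc1ccc(/C=N/NC(=O)Nc2ccc(Oc3ccnc4[nH]ccc34)c(F)c2)cc1`: 850 nM
- compound 3 `O=C(N/N=C/c1ccc(F)cc1Cl)Nc1ccc(Oc2ccnc3[nH]ccc23)c(F)c1`: 1110 nM

Compound 3 gives 1110 nM, which lies within the scatter of both other measured compounds, so the three cannot be ranked on these numbers.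

The change under consideration leads to compound 4 `O=C(N/N=C/c1ccc(O)cc1O)Nc1ccc(Oc2ccnc3[nH]ccc23)c(F)c1`: 2,4-dihydroxyphenyl in place of 2-chloro-4-fluorophenyl on a carbon with a double bond to nitrogen.

Among the compounds with values here, three measured steps bear on it. Two replace the group on the same carbon with a double bond to nitrogen: a 1.1-fold higher number from compound 1 to compound 3 (0.05 log units; within the scatter) and a 1.3-fold higher number from compound 2 to compound 3 (0.12 log units; within the scatter). The third is a smaller change, cyano in place of bromo on an aromatic carbon: a 1.2-fold lower number from compound 1 to compound 2 (0.07 log units; within the scatter). All three are small, and none leaves the scatter. On the evidence of these steps from compound 1, compound 2 and compound 3, no step beyond the scatter is expected in this assay, and no direction can be given. Within the data shown here, no measured compound carries 2,4-dihydroxyphenyl at this place, which leaves the expectation uncertain and the range wide.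

The expected change is a 1.1-fold lower number from compound 3 to compound 4 (0.05 log units; within the scatter).

For compound 4 the estimated value is 1000 nM, with an expected range of 350 nM to 3000 nM.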

Compound 4, half-maximal inhibitory concentration: 4550 nM
The estimate for compound 4 lay 4.6-fold (0.66 log units) below the measured number; measured number outside the range, above it.
By their numbers in this assay, from the lowest: compounds 2, 1 and 3 (each within the scatter of the next); then compound 4.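

Across the halogen and nitrile aryl groups, the carbon with a double bond to nitrogen gave no separation in this assay, whereas 2,4-dihydroxyphenyl at that place gives a 4.1-fold higher number from compound 3 to compound 4 (0.61 log units; beyond the scatter) and a 5.4-fold higher number from compound 2 to compound 4 (0.73 log units; beyond the scatter) and a 4.6-fold higher number from compound 1 to compound 4 (0.66 log units; beyond the scatter) as steps beyond the scatter, all towards weaker inhibition. The position is therefore not indifferent to the aryl group, and among the four compounds shown the tolerance seen for compounds 1, 2 and 3 does not extend to compound 4, whose group brings 2 hydrogen-bond donors where 2-chloro-4-fluorophenyl has 0. No measurement at hand accounts for this loss of activity.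

The step from compound 3 removes chlorine and fluorine and adds two hydroxyl groups in a single change, so the compounds shown cannot assign it to either hydroxyl group or to the loss of the halogens. As far as these compounds go, whether 4-hydroxyphenyl or 2-hydroxyphenyl alone gives the same step remains open, as does the outcome for 2,4-dimethoxyphenyl, which keeps the oxygens but replaces the hydroxyl hydrogens with methyl groups.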